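Thiophene in Place of Chlorophenyl on an Inactive Core

A few compounds are considered here, and "the series" means these few. Any claim that something is new, unique, unknown or untested is made for them only; others in the source may bear on it.

Compound 1 `Cc1ccc(-c2cn(/N=C/c3cc4ccccc4nc3Cl)c(N)n2)cc1` in a functional assay on DLD-1 cells (Homo sapiens) for cytotoxicity, read by MTT assay, with a stated time of 48 h (on this read-out higher numbers stand for weaker inhibition and lower numbers for stronger inhibition), gives > 50000 nM, a limit of the assay, not a number.
Compound 2 `Nc1nc(-c2ccc(Cl)cc2)cn1/N=C/c1cc2ccccc2nc1Cl` in this assay gives > 50000 nM, again only a limit.

Compound 2 therefore stands only at a limit; nothing finer is known. For the measured compounds named here, the one measured step, a step that the two limits leave unreadable from compound 1 to compound 2, cannot be sized, since the limit of > 50000 nM in this assay, at which 2 of the 2 values shown sit, applies to both values. Compound 3 `Nc1nc(-c2cccs2)cn1/N=C/c1cc2ccccc2nc1Cl` differs from compound 2 by thiophen-2-yl in place of 4-chlorophenyl on an aromatic carbon. No readable step bears on this change, so no step beyond the scatter in this assay is expected, in either direction. Compound 3 is estimated at 50000 nM, between 10000 nM and 100000 nM. This estimate means an expected step of a number no higher from compound 2 to compound 3 (the limit leaves the size open), most likely reported as a limit again.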

Compound 3, half-maximal inhibitory concentration: 10300 nM
Compound 3: middle estimate off by 4.9-fold (0.69 log units), on the high side; low and high end bracket the measured number.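

This position on the core can register a change: in this assay, thiophen-2-yl in place of 4-chlorophenyl brings an at least 4.8-fold lower number from compound 2 to compound 3 (0.68 log units; beyond the scatter), and in place of 4-methylphenyl it brings an at least 4.8-fold lower number from compound 1 to compound 3 (0.68 log units; beyond the scatter). For the compounds shown here, the earlier pair gave no readable step, so this is the first sign that the group here matters in this read-out. The true sizes of both steps remain unknown, because the two starting compounds give only a limit: the limit of > 50000 nM in this assay, at which 2 of the 3 values shown sit.

Whether the sulfur or the smaller ring accounts for these steps stays open. Also open, as far as these compounds go, is how furan-2-yl or an amine at this position would read.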